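Acylhydrazones on two chlorinated cores: amide aryl swap

A few compounds are considered here, and "the series" means these few. Any claim that something is new, unique, unknown or untested is made for them only; others in the source may bear on it.

Measured so far:
compound 1, `O=C(N/N=C/C1=C(Cl)c2ccccc2CCC1)c1cccnc1`, gives 7500 nM in a functional assay on HeLa cells (Homo sapiens) for inhibition, read by sulforhodamine B assay, with a stated time of 48 h; a higher number here means a weaker inhibitor of growth, a lower number a stronger inhibitor of growth
compound 2, `O=C(N/N=C/C1=C(Cl)c2ccccc2CCC1)c1cccc(I)c1`, gives 6300 nM in this assay
compound 3, `Cc1cc2c(cc1C)C(Cl)=C(/C=N/NC(=O)c1cccnc1)CCC2`, gives 650 nM in this assay

Compound 1 and compound 2 share one core; compound 3 sits on a second core and carries the same pyridin-3-yl amide as compound 1. The difference between the two cores is not broken down here. What the values show is that compound 3 gives the lowest number of the three in this assay, and its gaps to compound 2 and to compound 1 both lie beyond the scatter.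

Among the measured compounds shown here, the one single-point change measured is from compound 1 to compound 2: 3-iodophenyl in place of pyridin-3-yl on a carbonyl carbon. In this assay this gave a 1.2-fold lower number from compound 1 to compound 2 (0.08 log units; within the scatter), so the two values stand within the scatter of each other and no order can be read from them.

Compound 4, `Cc1cc2c(cc1C)C(Cl)=C(/C=N/NC(=O)c1cccc(I)c1)CCC2`, is not yet measured. It carries the same change on the core of compound 3: 3-iodophenyl in place of pyridin-3-yl on a carbonyl carbon. The place is the same word for word as in the measured pair, so this is the same change, and among the compounds shown it occurs only in these pairs.

The step from compound 3 to compound 4 is expected to be small, about the size of a 1.2-fold lower number from compound 1 to compound 2 (0.08 log units; within the scatter), namely a 1.2-fold lower number from compound 3 to compound 4 (0.07 log units; within the scatter); this rests on that one measured pairing alone. Compound 4 is therefore estimated at 550 nM in this assay, with an expected range from 250 nM to 1300 nM.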

Compound 4, concentration for 50% growth inhibition: > 100000 nM
Compound 4 gave a limit, no number; the forecaster's own chance of this, stated with the estimate: 3%; middle value at least 180-fold (2.25 log units) away from the limit.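

In this assay compound 4 gives > 100000 nM, which is a limit of the assay and not a number: the limit of > 100000 nM in this assay, at which 1 of the 4 values shown sits.

Read with that limit, 3-iodophenyl in place of pyridin-3-yl on a carbonyl carbon gives an at least 150-fold higher number from compound 3 to compound 4 (2.18 log units; beyond the scatter), so the near-silent step on the core of compound 1 does not carry over to the core of compound 3: the same change on two cores in this assay, a 1.2-fold lower number (0.08 log units; within the scatter) from compound 1 to compound 2 and an at least 150-fold higher number (2.18 log units; beyond the scatter) from compound 3 to compound 4, at least 180-fold (2.26 log units) apart, beyond the scatter of two such steps

On these data alone, in these two pairs, then, the outcome of the change depends on the core it is made on, but this does not show which part of the core difference matters, the true size of the second step stays unknown, and two pairs give no rule for any further core.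

The compounds shown leave open whether the result on the core of compound 3 follows the arrival of the iodine or the departure of the ring nitrogen, and a plain phenyl on that core would separate the two. Also open, as far as these compounds go, is how other groups on the same ring behave on each core, such as an amine or a carboxylic acid in place of the iodine.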